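Solubility notes on the shared-core series, toward compound 4

The source may report more compounds than this note shows. Statements on the series, on what has been measured and on what is new or still open speak of the compounds shown alone.

Measured so far in a physicochemical assay for solubility; a higher number here means a more soluble compound, a lower number a less soluble compound:
- compound 1, `CN(C)c1ccc(C(=O)N2CCC(NS(=O)(=O)c3cc(S(=O)(=O)c4ccccc4)ccc3C(F)(F)F)CC2)cc1`, compound 1 gives 50000 nM
- compound 2, `O=C(c1ccc(Cl)nc1)N1CCC(NS(=O)(=O)c2cc(S(=O)(=O)c3ccccc3)ccc2C(F)(F)F)CC1`, compound 2 gives 25000 nM
- compound 3, `N#Cc1cccc(S(=O)(=O)N2CCC(NS(=O)(=O)c3cc(S(=O)(=O)c4ccccc4)ccc3C(F)(F)F)CC2)c1`, compound 3 gives 6300 nM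

Compound 3 stands lowest of the three in this assay: the step of a 7.9-fold lower number from compound 1 to compound 3 (0.90 log units; beyond the scatter) and the step of a 4.0-fold lower number from compound 2 to compound 3 (0.60 log units; beyond the scatter) both lie beyond the scatter, while the step of a 2.0-fold lower number from compound 1 to compound 2 (0.30 log units; within the scatter) is within it. The two steps that reach compound 3 are the ones that bear on the next move, since each of them swaps an aryl carbonyl on the ring nitrogen for the (3-cyanophenyl)sulfonyl and each lowers the number by a modest amount.

Compound 4, `O=C([C@@H]1CCNC1)N1CCC(NS(=O)(=O)c2cc(S(=O)(=O)c3ccccc3)ccc2C(F)(F)F)CC1`, is the next compound for this assay. The change from compound 3 is (pyrrolidin-3-yl)carbonyl in place of (3-cyanophenyl)sulfonyl on an amine nitrogen in a ring. It reverses the direction of those two steps, bringing a carbonyl back onto the ring nitrogen, though the group that enters is not one of the aryl carbonyls already seen, so the size is only loosely anchored.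

The expectation is a rise, at least of the size of the measured steps, giving an estimated step of a 13-fold higher number from compound 3 to compound 4 (1.10 log units; beyond the scatter). Compound 4 is expected to give about 80000 nM, within the range 20000 nM to 300000 nM.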

Compound 4, solubility: 12500 nM
Beside the measured number, compound 4's estimate is 6.4-fold (0.81 log units) above it; the measured number lies below the stated range.
By their numbers in this assay, from the lowest: compounds 3, 4, 2 and 1 (each within the scatter of the next, the first and the last beyond it).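

In this assay, the move back to a carbonyl on the amine nitrogen in a ring gives a 2.0-fold higher number from compound 3 to compound 4 (0.30 log units; within the scatter) as its reading, so this sulfonyl-to-carbonyl exchange does not carry a fixed size across the groups shown. Compound 4 sits within the scatter of both compound 3 and compound 2, although those two lie beyond the scatter of each other. On the carbonyl carbon, the pyrrolidin-3-yl, the only non-aromatic ring among these groups, gives a 2.0-fold lower number from compound 2 to compound 4 (0.30 log units; within the scatter) against the 6-chloropyridin-3-yl and a 4.0-fold lower number from compound 1 to compound 4 (0.60 log units; beyond the scatter) against the 4-(dimethylamino)phenyl, so only the latter exchange reaches beyond the scatter.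

The compounds shown leave open whether the ring nitrogen of the pyrrolidin-3-yl has any bearing on the number, which a cyclopentyl on the carbonyl carbon or an acetyl on that nitrogen would test. They also leave open how an open-chain amine, such as a dimethylaminomethyl group on the same carbonyl carbon, would compare with compound 4.

No measurement in hand bears on the reason for this result.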